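Cycloheptyl to fluorophenylpropyl on the shared core

The compounds below may be only part of what the source reports. "The series", "measured", "known", "first", "only" and "open" are said of these compounds alone.

Three compounds of this series have numbers in a functional assay on the whole organism for inhibition, with Rattus norvegicus as the target; on this read-out higher numbers stand for an effect only at larger amounts of compound and lower numbers for an effect already at smaller amounts. Compound 1 `O=C(O)CSC(CCCc1ccc(Cl)cc1)c1ccc(OCc2ccc3ccccc3n2)cc1` gives 1.6 mg/kg in this assay. Compound 2 `C/C(CCCC(=O)O)=N\OC(c1ccc(OCc2ccc3ccccc3n2)cc1)C1CCCCC1` gives 3 mg/kg in this assay. Compound 3 `C/C(=N\OC(c1ccc(OCc2ccc3ccccc3n2)cc1)C1CCCCCC1)C(=O)O` gives 0.7 mg/kg in this assay, the lowest of the three numbers; compound 1 stands nearest, its number higher by a margin beyond the scatter, and compound 2 stands furthest, also beyond the scatter. No two of these three differ in a single place, so no single-point step can be read from the measured set.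

Compound 4 `C/C(=N\OC(CCCc1ccc(F)cc1)c1ccc(OCc2ccc3ccccc3n2)cc1)C(=O)O` awaits measurement in this assay. It differs from compound 3 in one place: 3-(4-fluorophenyl)propyl in place of cycloheptyl on a saturated chain carbon bound to an aromatic carbon and an oxygen. Among the measured compounds, compound 1 carries a chain of the same kind as the group that enters, and compound 1 gives 1.6 mg/kg in this assay. On that basis the step from compound 3 to compound 4 is expected to be a 1.9-fold higher number from compound 3 to compound 4 (0.27 log units; within the scatter), a modest rise that may or may not clear the scatter, because compound 1 gives 1.6 mg/kg. Compound 4 is therefore estimated to give 1.3 mg/kg in this assay, with an expected range from 0.5 mg/kg to 3.5 mg/kg.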

Compound 4, dose for half-maximal effect: 2.6 mg/kg
Beside the measured number, compound 4's estimate is 2.0-fold (0.30 log units) below it; low and high end bracket the measured number.
By their numbers in this assay, from the lowest: compound 3; then compounds 1, 4 and 2 (each within the scatter of the next).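

On a saturated chain carbon bound to an aromatic carbon and an oxygen, the series now has its first single-place comparison: in this assay, 3-(4-fluorophenyl)propyl in place of cycloheptyl gives a 3.7-fold higher number from compound 3 to compound 4 (0.57 log units; beyond the scatter), so this position is sensitive to the exchange, and the seven-membered carbon ring is the better of the two groups tested here. Nothing in the data shown accounts for the size or direction of this step. The other pairs among these compounds differ in more than one place, so no steps can be read from them, and the comparison rests on this single pair.

The exchange alters several features at once, replacing a non-aromatic ring with an aromatic ring on a three-carbon chain and bringing in fluorine, and the compounds shown do not separate these contributions. On these data alone, an unsubstituted 3-phenylpropyl group would isolate the fluorine, while a shorter 2-(4-fluorophenyl)ethyl chain on the shared core would test the chain length, and the response of this position to either remains open.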